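Swapping the Sulfonamide for a Sulfone in an Acetylene Series

This account rests on a few compounds, and the source may have more. Where it says the series, first, only, none or still open, it means among the compounds named here.

Measured so far:
compound 1 `COCCNS(=O)(=O)c1ccc(C)c(C#Cc2cc(Cl)ccc2OCC(=O)O)c1` gives 88 nM
compound 2 `Cc1ccc(S(=O)(=O)N2CCCCC2C)cc1C#Cc1cc(Cl)ccc1OCC(=O)O` gives 310 nM

Both were tested in a functional assay on cells for antagonist activity at prostaglandin D2 receptor 2 (Homo sapiens), read by flow cytometry, with a stated time of 10 min; a higher number here means a weaker inhibitor, a lower number a stronger inhibitor. Among the measured compounds shown here, compound 2 holds the higher of the two numbers, with compound 1 as its only neighbour at a 3.5-fold higher number from compound 1 to compound 2 (0.55 log units; beyond the scatter). Compound 3 `Cc1ccc(S(=O)(=O)CC(C)C)cc1C#Cc1cc(Cl)ccc1OCC(=O)O` is not yet measured; it differs from compound 2 in one place: isobutyl in place of 2-methylpiperidin-1-yl on a sulfonyl sulfur. For the measured compounds named here, only the step from compound 1 to compound 2 bears on this change, and it was modest. Because compound 2 sits at 310 nM after a modest rise, compound 3 is expected to return part of the way, an estimated 1.7-fold lower number from compound 2 to compound 3 (0.24 log units; within the scatter), giving an expected 180 nM within 50 nM to 650 nM.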

Compound 3, half-maximal inhibitory concentration: 120 nM
Compound 3: middle estimate off by 1.5-fold (0.18 log units), on the high side; the range from low to high includes it.
By their numbers in this assay, from the lowest: compounds 1 and 3 (each within the scatter of the next); then compound 2.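

Compound 3 shows that the sulfonyl sulfur need not carry a nitrogen: isobutyl, made only of carbon, gives a 1.4-fold higher number from compound 1 to compound 3 (0.13 log units; within the scatter). Replacing the ring of 2-methylpiperidin-1-yl with the smaller, ring-free isobutyl gives a 2.6-fold lower number from compound 2 to compound 3 (0.41 log units; beyond the scatter), so among these three sulfonyl groups only the 2-methylpiperidin-1-yl group stands apart. No available evidence explains this difference. Still open, as far as these compounds go, is how a shorter chain such as ethyl, or an all-carbon ring such as cyclohexyl, would behave on the same sulfur.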